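Halogen and methyl swaps on the shared core, growth inhibition

A few compounds are considered here, and "the series" means these few. Any claim that something is new, unique, unknown or untested is made for them only; others in the source may bear on it.

Measured compounds:
- compound 1 `Nc1ccccc1NC(=O)c1ccc(CSc2ccc(Br)cc2)cc1`: 4.35%
- compound 2 `Cc1ccc(SCc2ccc(C(=O)Nc3ccccc3N)cc2)cc1`: 17.5%
- compound 3 `Nc1ccccc1NC(=O)c1ccc(CSc2ccc(F)cc2)cc1`: 19.4%

In a functional assay on A-375 cells (Homo sapiens) for inhibition, read by CCK-8 assay, with a stated time of 72 h, tested at 2 uM (a lower number here means less inhibition of growth, a higher number more inhibition of growth at the concentration tested), compound 3 gives the highest of the three numbers, but its lead over compound 2 is only a number 1.9 percentage points higher from compound 2 to compound 3 (within the scatter), which is within the scatter, so the two cannot be ordered. Among the measured compounds shown here, the one step clearly beyond the scatter runs from the bromo compound: a number 15.1 percentage points higher from compound 1 to compound 3 (beyond the scatter), and likewise a number 13.2 percentage points higher from compound 1 to compound 2 (beyond the scatter).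

Compound 4 `Nc1ccccc1NC(=O)c1ccc(CSc2ccc(Cl)cc2)cc1` is not yet measured. It differs from compound 3 by chloro in place of fluoro on an aromatic carbon; one halogen on the same aromatic carbon replaces another. The step that bears on this is the halogen swap from compound 1 to compound 3, with fluoro and bromo at the two ends of the range seen so far. Chloro stands between them in size, and the only step in this series is a fall toward bromo, so an intermediate number is expected in this assay, a modest drop from compound 3 that may or may not exceed the scatter: a number 7.4 percentage points lower from compound 3 to compound 4 (within the scatter). Compound 4 is therefore estimated at 12%, with a range of 2% to 24%.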

Compound 4, percent growth inhibition at one concentration: 25.3%
For compound 4 the middle estimate is 13.3 percentage points below the measured one; the measured number lies above the stated range.
By their numbers in this assay, from the lowest: compound 1; then compounds 2, 3 and 4 (each within the scatter of the next).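

At this aromatic carbon, para to a large group, the halogens do not fall in a graded run: in this assay, chloro in place of fluoro gives a number 5.9 percentage points higher from compound 3 to compound 4 (within the scatter), so the fall seen earlier between fluoro and bromo cannot be extended to chloro. Chloro also cannot be separated from methyl, with a number 7.8 percentage points higher from compound 2 to compound 4 (within the scatter), so compounds 2, 3 and 4 form one group, while the only clear change in the series is a number 21 percentage points higher from compound 1 to compound 4 (beyond the scatter), which sets the bromo compound apart from that group and makes compound 1 the exception to any shared reading of these substituents. Nothing available explains why chloro and bromo part here, and no measurement bears on the difference.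

Still open, on these data alone, is whether a methoxy, an amine, a carboxylic acid or a trifluoromethyl group on the same aromatic carbon would stay with compounds 2, 3 and 4 or fall toward compound 1. With a read-out at one concentration only, the series also leaves open whether compounds 2, 3 and 4 would separate over a range of concentrations, or whether the low number of compound 1 would hold.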